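Exchanging 4-methyl-1,3-thiazol-2-yl for 6-aminopyridazin-3-yl

The source may hold more compounds than are shown below. What is called first, only, known or untested is meant among the compounds shown, and "the series" means these compounds.

Compound 1 `Cc1csc(-c2cc(NC(=O)c3ccc(OCc4ccccn4)cc3)c(C)cc2C)n1`: 513 mL.min-1.g-1
Compound 2 `Cc1cc(C)c(-c2c(C)nn(C)c2C)cc1NC(=O)c1ccc(OCc2ccccn2)cc1`: 122 mL.min-1.g-1
Compound 3 `Cc1cc(C)c(-c2cccnc2)cc1NC(=O)c1ccc(OCc2ccccn2)cc1`: 62 mL.min-1.g-1

In an ADME assay on microsomes from liver (Homo sapiens) for metabolic stability (on this read-out higher numbers stand for fast clearance and lower numbers for slow clearance), compound 1 gives the highest number of the three measured compounds. Compound 2 sits nearest to it, with a 4.2-fold lower number from compound 1 to compound 2 (0.62 log units; beyond the scatter), and compound 3 sits furthest, with an 8.3-fold lower number from compound 1 to compound 3 (0.92 log units; beyond the scatter). Between those two, a 2.0-fold lower number from compound 2 to compound 3 (0.29 log units; within the scatter), so their values cannot be ordered.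

The step to compound 4 `Cc1cc(C)c(-c2ccc(N)nn2)cc1NC(=O)c1ccc(OCc2ccccn2)cc1` changes compound 1 in one place: 6-aminopyridazin-3-yl in place of 4-methyl-1,3-thiazol-2-yl on an aromatic carbon. The two measured steps out of compound 1 bear on this one, since each also replaces the 4-methyl-1,3-thiazol-2-yl on the same aromatic carbon with another ring, and both gave modest decreases in this assay. The entering 6-aminopyridazin-3-yl is, like pyridin-3-yl, a six-membered aromatic ring, so a decrease of a similar, modest size is expected, a 7.3-fold lower number from compound 1 to compound 4 (0.87 log units; beyond the scatter). Compound 4 is therefore estimated at 70 mL.min-1.g-1, with a range from 25 mL.min-1.g-1 to 200 mL.min-1.g-1.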

Compound 4, intrinsic clearance in microsomes: < 4 mL.min-1.g-1
Compound 4: only a limit was reported; the forecaster's own chance of this, stated with the estimate: 10%; middle value at least 17-fold (1.24 log units) from the limit.
By their numbers in this assay, from the lowest: compounds 3 and 2 (each within the scatter of the next); then compound 1. At a limit, below all of these: compound 4.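

In this assay compound 4 gives < 4 mL.min-1.g-1 as a limit and not as a number. The change brings an at least 120-fold lower number from compound 1 to compound 4 (2.10 log units; beyond the scatter) and counts as large, whereas the two earlier replacements of 4-methyl-1,3-thiazol-2-yl on this aromatic carbon were modest. The 6-aminopyridazin-3-yl also stands apart from both other entering rings, with an at least 15-fold lower number from compound 3 to compound 4 (1.19 log units; beyond the scatter) and with an at least 30-fold lower number from compound 2 to compound 4 (1.48 log units; beyond the scatter) and so the ring at this position alone can bring the read-out down to its limit: the limit of < 4 mL.min-1.g-1 in this assay, at which 1 of the 4 values shown sits.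

The compounds shown leave open whether the amine or the pyridazine ring carries this step. A plain pyridazin-3-yl and a 6-aminopyridin-3-yl on the shared core would separate the two.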